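The source may hold more compounds than are shown below. What is called first, only, known or untested is meant among the compounds shown, and "the series" means these compounds.

Measured in a functional assay on HCT-116 cells (Homo sapiens) for cytotoxicity, read by MTT assay, with a stated time of 48 h; on this read-out lower numbers stand for stronger inhibition and higher numbers for weaker inhibition:
- compound 1 `COc1cc(/C=C/c2ccc(OCCCCC(=O)NO)cc2)cc(OC)c1`: 3350 nM
- compound 2 `COc1cc(/C=C/c2ccc(OCCCCCCCC(=O)NO)cc2)cc(OC)c1`: 12600 nM

Compound 2 stands at the higher of the two numbers, 12600 nM. Compound 3 `COc1cc(/C=C/c2ccc(OCc3cccc(C(=O)NO)c3)cc2)cc(OC)c1` changes it as follows: 3-(hydroxycarbamoyl)phenyl in place of 6-(hydroxycarbamoyl)hexyl on a saturated chain carbon bound to an oxygen on an aromatic ring. Within the data shown here, the ring-bearing group has no measured precedent. Among the measured compounds shown here, the only step that bears on it is a 3.8-fold higher number from compound 1 to compound 2 (0.58 log units; beyond the scatter), a change of chain length that is beyond the scatter, and it offers only indirect guidance. With compound 2 at the top of this small range, a modest move to a lower number in this assay is expected, as a 2.3-fold lower number from compound 2 to compound 3 (0.36 log units; beyond the scatter). For compound 3 the estimated value is 5500 nM, with an expected range of 1800 nM to 17000 nM.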

Compound 3, half-maximal inhibitory concentration: 13700 nM
Estimate against measurement, compound 3: 2.5-fold (0.40 log units) below; measured number inside the range.
By their numbers in this assay, from the lowest: compound 1; then compounds 2 and 3 (each within the scatter of the next).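

In this assay, 3-(hydroxycarbamoyl)phenyl in place of 6-(hydroxycarbamoyl)hexyl gives a 1.1-fold higher number from compound 2 to compound 3 (0.04 log units; within the scatter), so on this saturated chain carbon the ring-bearing group and the longer chain cannot be told apart. Against 3-(hydroxycarbamoyl)propyl the same group gives a 4.1-fold higher number from compound 1 to compound 3 (0.61 log units; beyond the scatter), which leaves compound 1 with the lowest number, its steps to both others being beyond the scatter. Nothing at hand gives a cause for either step.

Open, from the compounds shown here alone, is how a shorter 2-(hydroxycarbamoyl)ethyl chain would read at this carbon. Also open, going by these compounds, is whether a carboxylic acid in place of hydroxycarbamoyl would keep numbers in this range.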